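The source may report more compounds than this note shows. Statements on the series, on what has been measured and on what is new or still open speak of the compounds shown alone.

Measured so far in the series:
compound 1, `COc1cc2c(Oc3ccc(NC(=O)c4cc(-c5ccccc5)ccn4)cc3F)ccnc2cc1OCCCN1CCN(C)CC1`: 82 nM
compound 2, `COc1cc2c(Oc3ccc(NC(=O)c4cc(-c5ccccc5)ccn4)cc3F)ccnc2cc1OCCCN1CCCC1`: 120 nM

Both numbers come from a functional assay on HT-29 cells (Homo sapiens) for cytotoxicity, read by MTT assay, with a stated time of 72 h; a higher number here means a weaker inhibitor, a lower number a stronger inhibitor. Among the measured compounds shown here, compound 2 gives the higher of the two numbers, but the only step to it, a 1.5-fold higher number from compound 1 to compound 2 (0.17 log units; within the scatter), lies within the scatter, so on these two numbers compound 2 and compound 1 are not separable. That step exchanges the amine at the end of the chain and leaves the rest of the shared core untouched.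

Compound 3, `COc1cc2c(Oc3ccc(NC(=O)c4cc(-c5ccc(C)cc5)ccn4)cc3F)ccnc2cc1OCCCN1CCCC1`, has not been measured in this assay. It differs from compound 2 by methyl in place of hydrogen on an aromatic carbon, a methyl on an aromatic carbon of a six-membered aromatic ring of carbon only, para to a large group. For the measured compounds named here, no measured step bears on this part of the molecule: the single step, from compound 1 to compound 2, concerns the chain amine and was itself within the scatter. With nothing in the data pointing either way, the expected step of no change at the digits printed from compound 2 to compound 3 (within the scatter) is none beyond the scatter. Compound 3 is therefore estimated at 120 nM, with a range from 45 nM to 320 nM.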

Compound 3, half-maximal inhibitory concentration: 350 nM
Estimate against measurement, compound 3: 2.9-fold (0.46 log units) below; the measured number lies above the stated range.
By their numbers in this assay, from the lowest: compounds 1 and 2 (each within the scatter of the next); then compound 3.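

In this assay, the change from phenyl to 4-methylphenyl gives a 2.9-fold higher number from compound 2 to compound 3 (0.46 log units; beyond the scatter), a modest step and the only one shown so far that lies beyond the scatter. The other step shown, the exchange of the chain amine, gives a 1.5-fold higher number from compound 1 to compound 2 (0.17 log units; within the scatter) and does not separate its two compounds, so this aromatic carbon is the one place in the series where a change has moved the number clearly, and the addition of a single carbon atom was enough to do so. Nothing available explains the higher number for compound 3.

As far as these compounds go, this reading rests on a single pair, so it remains open whether the higher number is particular to methyl or would also appear with chlorine, methoxy or a longer alkyl chain on the same carbon. From the compounds shown here alone, it is also open whether phenyl to 4-methylphenyl would give a similar step with 4-methylpiperazin-1-yl, rather than pyrrolidin-1-yl, at the end of the chain.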